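From Methyl to Methoxy at the Assay Limit

The source may hold more compounds than are shown below. What is called first, only, known or untested is meant among the compounds shown, and "the series" means these compounds.

Measured in a functional assay on the whole organism for antagonist activity, with Mus musculus as the target (a higher number here means that more compound is needed for the effect, a lower number that less compound is needed), where every entry is a limit and not a number:
Compound 1 `Cn1c(-c2cccs2)nnc1S(C)(=O)=O`: > 200 mg/kg
Compound 2 `Cc1ccc(-c2nnc([S+](C)[O-])n2C)cc1`: > 200 mg/kg
Compound 3 `Cc1ccc(-c2nnc(S(C)(=O)=O)n2C)cc1`: > 200 mg/kg

Compound 3 gives only a limit of > 200 mg/kg. Compound 3 thus shares (the limit of > 200 mg/kg in this assay, at which 3 of the 3 values shown sit).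

Compound 4 `COc1ccc(-c2nnc(S(C)(=O)=O)n2C)cc1` carries methoxy in place of methyl on an aromatic carbon, para to a large group: methoxy in place of methyl on an aromatic carbon. Going by the values given here, no measured step covers this change. The nearest one is a step that the two limits leave unreadable from compound 2 to compound 3, which concerns a different group and offers no size to carry over. No step beyond the scatter can therefore be expected in either direction. The expected step is a step that the limit leaves unreadable from compound 3 to compound 4. Compound 4 is estimated at 250 mg/kg, with an expected range of 100 mg/kg to 600 mg/kg.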

Compound 4, dose for half-maximal effect: > 200 mg/kg
Compound 4 gave a limit, no number; the forecaster's own chance of this, stated with the estimate: 75%; the middle value does not contradict the limit.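

Compound 3 and compound 4 each give only a limit in this assay, so no step from methyl to methoxy can be read: the limit of > 200 mg/kg in this assay, at which 4 of the 4 values shown sit.

The compounds shown leave open what dose any of them needs for the effect.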